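Shortening the Linker Chain of Compound 1

A few compounds are considered here, and "the series" means these few. Any claim that something is new, unique, unknown or untested is made for them only; others in the source may bear on it.

Compound 1 `Cc1c(-c2ccc(O)c(O)c2)n(CCCCOc2ccccc2)c2ccc(O)cc12` is the starting point. In a functional assay on HeLa cells (Homo sapiens) for inhibition, read by trypan blue exclusion, with a stated time of 72 h (on this read-out higher numbers stand for weaker inhibition of growth and lower numbers for stronger inhibition of growth), compound 1 gives 10000 nM, the higher of the two numbers recorded. Among the measured compounds shown here, its nearest neighbour is compound 3 `Cc1c(-c2ccc(O)cc2)n(CCCCOc2ccccc2)c2ccc(O)cc12`, which gives 4000 nM; the single measured step, a 2.5-fold lower number from compound 1 to compound 3 (0.40 log units; beyond the scatter), concerns only a hydroxy group. Compound 2 `CCCn1c(-c2ccc(O)cc2)c(C)c2ccccc21` is recorded only as a limit, > 20000 nM, so it offers no number to compare.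

Compound 4 `Cc1c(-c2ccc(O)c(O)c2)n(CCCOc2ccccc2)c2ccc(O)cc12` keeps everything in compound 1 except one change: phenoxy in place of phenoxymethyl on a saturated chain carbon, three bonds along the chain from an aromatic nitrogen. For the measured compounds named here, no measured step touches this chain, so nothing on record points to a shift in either direction, and the expected step is none beyond the scatter, no change at the digits printed from compound 1 to compound 4 (within the scatter). Compound 4 is therefore expected to give 10000 nM, with a range from 4000 nM to 25000 nM.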

Compound 4, concentration for 50% growth inhibition: 18000 nM
Compound 4: the middle estimate sits 1.8-fold (0.26 log units) below what was measured, and the stated range covers the measured number.
By their numbers in this assay, from the lowest: compound 3; then compounds 1 and 4 (each within the scatter of the next). At a limit, above all of these: compound 2.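

In this assay, among the compounds shown here, replacing phenoxymethyl with phenoxy on the saturated chain gives a 1.8-fold higher number from compound 1 to compound 4 (0.26 log units; within the scatter), the first reading on this chain, and it shows that this shortening leaves growth inhibition unchanged within the usual scatter. Compound 2 is recorded only at a limit, and that limit also marks how little room remains for reading weaker compounds: the limit of > 20000 nM in this assay, at which 1 of the 4 values shown sits.

On these data alone, whether a longer chain or an amine in place of phenoxy would move the number stays open. So does whether the same shortening would behave alike on compound 3.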